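The source may report more compounds than this note shows. Statements on the series, on what has been measured and on what is new or still open speak of the compounds shown alone.

Measured so far:
- compound 1 `O=C(COc1ccc2cc(/C=C3/SC(=O)NC3=O)ccc2c1)Nc1ccc(F)cc1F`: 3900 nM
- compound 2 `Cc1cc(Br)ccc1NC(=O)COc1ccc2cc(/C=C3/SC(=O)NC3=O)ccc2c1`: 550 nM

Among the measured compounds shown here, in an assay on isolated protein for inhibition of histone deacetylase 4 (Homo sapiens), with a stated time of 1 h (a lower number here means a stronger inhibitor, a higher number a weaker inhibitor), compound 2 holds the lower of the two numbers; the only measured step, a 7.1-fold lower number from compound 1 to compound 2 (0.85 log units; beyond the scatter), separates it from compound 1 and lies beyond the scatter. Compound 3 `O=C(COc1ccc2cc(/C=C3/SC(=O)NC3=O)ccc2c1)Nc1ccc([N+](=O)[O-])cc1` is not yet measured; it differs from compound 2 by 4-nitrophenyl in place of 4-bromo-2-methylphenyl on an amide-type nitrogen. For the measured compounds named here, the one step that bears on this change is the earlier exchange of the aryl group on the same amide nitrogen, a 7.1-fold lower number from compound 1 to compound 2 (0.85 log units; beyond the scatter), which was modest in size. Going by the values given here, that step shows the number is sensitive to which aryl group sits on the amide nitrogen, but no measured pair tests 4-nitrophenyl itself, so the direction rests on the exchange alone. The expectation is a move back toward the region of compound 1, with a step of a 2.7-fold higher number from compound 2 to compound 3 (0.44 log units; beyond the scatter) in this assay. Compound 3 is therefore estimated at 1500 nM, within 450 nM to 5000 nM.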

Compound 3, half-maximal inhibitory concentration: 1700 nM
The estimate for compound 3 lay 1.1-fold (0.05 log units) below the measured number; the range from low to high includes it.
By their numbers in this assay, from the lowest: compound 2; then compound 3; then compound 1.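

In this assay, the aryl group on the amide-type nitrogen now has three measured members, and 4-nitrophenyl falls between the other two (a 3.1-fold higher number from compound 2 to compound 3 (0.49 log units; beyond the scatter); a 2.3-fold lower number from compound 1 to compound 3 (0.36 log units; beyond the scatter)). The number therefore responds to this exchange in both directions, with 4-bromo-2-methylphenyl still giving the lowest value of the three, though the exchange to 4-nitrophenyl alters several features of the aryl group at once. No measurement available here explains the differences among these aryl groups.

The compounds shown do not separate the contributions of the bromine and the methyl group within 4-bromo-2-methylphenyl. Also open, going by these compounds, is how the number would respond to an amine or a carboxylic acid on the phenyl ring, or to a longer chain between the amide and the shared core.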